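Oxazoline to Thiazoline on a Sulfonylmethyl Chain

The source may report more compounds than this note shows. Statements on the series, on what has been measured and on what is new or still open speak of the compounds shown alone.

Among the compounds with values here, compound 2 `O=S(=O)(CC1=NCCO1)c1n[nH]cc1-c1ccccc1` is the only compound of this set with a number in a functional assay, tested at 75 ug/mL; on this read-out lower numbers stand for a weaker effect and higher numbers for a stronger effect at the one concentration tested: compound 2 gives 55.6%. Compound 1 `O=S(=O)(CC1=NCCS1)c1c(-c2ccc(Cl)cc2)noc1-c1ccc(Cl)cc1` was reported as "not active" (no number reported), and compound 3 `O=S(=O)(CC1=NCCO1)C1=NNCC1c1ccccc1` likewise as "not active" (no number reported), so neither offers a number to compare with. Compound 4 `O=S(=O)(CC1=NCCS1)c1n[nH]cc1-c1ccccc1` keeps the core of compound 2 and differs by a group of 5 heavy atoms (3 carbon, 1 nitrogen, 1 sulfur; one five-membered non-aromatic ring with 2 hetero atoms) in place of a group of 5 heavy atoms (3 carbon, 1 nitrogen, 1 oxygen; one five-membered non-aromatic ring with 2 hetero atoms), on a saturated chain carbon bound to a sulfonyl sulfur. Within the data shown here, no step between measured compounds involving this change is available, and compound 1, which carries the entering group on a different core, gives no number. Compound 4 is therefore expected to stay close to compound 2, with a small step of a number 10.6 percentage points lower from compound 2 to compound 4 (beyond the scatter) in this assay that may not exceed the scatter. The estimate for compound 4 is 45%, within 20% to 70%.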

Compound 4, a percentage reported as activity, at one concentration (the size of the read-out at that concentration, not a potency): "not active" (no number reported)
Nothing numeric was reported for compound 4; no gap can be computed for the estimate.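

Within the data shown here, compound 4 carries no number, so no step from compound 2 to compound 4 can be read, and no evidence at hand bears on this result. The compounds shown leave open how large the effect of exchanging these two five-membered rings is.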